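This account rests on a few compounds, and the source may have more. Where it says the series, first, only, none or still open, it means among the compounds named here.

Going by the values given here, in an ADME assay on Vero cells (Chlorocebus sabaeus) for cytotoxicity, with a stated time of 72 h (on this read-out lower numbers stand for stronger inhibition and higher numbers for weaker inhibition), compound 1 (`O=C(CCN1CCN(c2ccc(C(F)(F)F)cc2)CC1)c1csc2ccccc12`) gives 237000 nM, the lower of the two numbers available so far. Among the compounds with values here, the only other measured compound, compound 2 (`O=C(CCN1CCN(c2ccc([N+](=O)[O-])cc2)CC1)c1csc2ccccc12`), gives 1710000 nM. Within the data shown here, the one measured step, a 7.2-fold higher number from compound 1 to compound 2 (0.86 log units; beyond the scatter), puts nitro in place of trifluoromethyl on an aromatic carbon, and it lies beyond the scatter.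

Compound 3 (`O=C(CCN1CCN(c2ccc(C(F)(F)F)cc2)CC1)c1ccc2ccccc2c1`) keeps the trifluoromethyl group of compound 1 but puts naphthalen-2-yl in place of 1-benzothiophen-3-yl on a carbonyl carbon. Among the measured compounds shown here, no measured step involves this place. The step of a 7.2-fold higher number from compound 1 to compound 2 (0.86 log units; beyond the scatter) therefore bears on the new change only loosely, as a rough guide to how far a single exchange can move the number in this small set, and it gives no direction. With no evidence for a shift either way, the expectation stays close to compound 1, with a wide margin. The estimated change is a 1.2-fold lower number from compound 1 to compound 3 (0.07 log units; within the scatter), which is expected to stay within the scatter. For compound 3 the expected value is 200000 nM, with an estimated range from 80000 nM to 550000 nM.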

Compound 3, half-maximal inhibitory concentration: 30100 nM
For compound 3 the middle estimate is 6.6-fold (0.82 log units) above the measured one; the whole stated range lies above it.
By their numbers in this assay, from the lowest: compound 3; then compound 1; then compound 2.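

Going by these compounds alone, the group on the carbonyl carbon clearly matters in this assay, and this is the first measured exchange at this place (a 7.9-fold lower number from compound 1 to compound 3 (0.90 log units; beyond the scatter)). The trifluoromethyl group stays the same in both compounds, so the step comes from replacing 1-benzothiophen-3-yl, with its five-membered aromatic ring holding a sulfur atom, by naphthalen-2-yl, which has 2 six-membered aromatic rings of carbon only. The compounds therefore show that the number can be moved beyond the scatter from two separate places, this one and the aromatic carbon that carries trifluoromethyl or nitro, although no measurement shown here explains why this exchange lowers the number.

This single exchange alters the ring size and removes the sulfur atom together, so it cannot show which of these differences counts, or whether naphthalen-2-yl would also lower the number in a compound carrying nitro instead of trifluoromethyl. It also leaves open how the number would respond to a quite different group on the carbonyl carbon, such as an amine or a carboxylic acid.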